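Dropping the Fluoro of Compound 2

A few compounds are considered here, and "the series" means these few. Any claim that something is new, unique, unknown or untested is made for them only; others in the source may bear on it.

For the measured compounds named here, compound 2 `C=CC(=O)Nc1cccc(Oc2ncnc3ccc(-c4ccc(F)nc4)cc23)c1` is one of two compounds so far measured in a functional assay on Raji cells (Homo sapiens) for inhibition, read by MTT assay, with a stated time of 48 h; a lower number here means a stronger inhibitor, a higher number a weaker inhibitor; compound 2 gives 11000 nM, the higher of the two numbers, while compound 1 `C=CC(=O)Nc1cccc(Nc2ncnc3ccc(-c4cnc5ccccc5c4)cc23)c1` gives 3500 nM. Compound 3 `C=CC(=O)Nc1cccc(Oc2ncnc3ccc(-c4cccnc4)cc23)c1`, not yet measured, differs from compound 2 by hydrogen in place of fluoro on an aromatic carbon, that is, 6-fluoropyridin-3-yl to pyridin-3-yl. Going by the values given here, no measured pair shows this change, so the step is expected to stay small, with no direction beyond the scatter: a 1.2-fold lower number from compound 2 to compound 3 (0.09 log units; within the scatter). Compound 3 is therefore estimated at 9000 nM, within a range from 3000 nM to 27000 nM.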

Compound 3, half-maximal inhibitory concentration: 14800 nM
Compound 3: middle estimate off by 1.6-fold (0.22 log units), on the low side, within the range that was stated.
By their numbers in this assay, from the lowest: compound 1; then compounds 2 and 3 (each within the scatter of the next).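

In this assay, for the compounds shown here, this is the first pair that differs in one place: hydrogen in place of fluoro, next to the ring nitrogen, gives a 1.3-fold higher number from compound 2 to compound 3 (0.13 log units; within the scatter) in this series. At this position, the two compounds therefore cannot be told apart, and the fluoro is not needed to keep the activity of compound 2. Nothing available explains this result.

From the compounds shown here alone, whether an amine, a methoxy group or a longer chain at this position would move the number beyond the scatter remains open. So does whether the same change would behave alike on the core of compound 1.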